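Trading an Aryl Ring for a Carboxyethyl Chain

This account rests on a few compounds, and the source may have more. Where it says the series, first, only, none or still open, it means among the compounds named here.

Compound 1 `CCCCCCCCc1ccc(OCC(=O)Cn2nnc(-c3cccc(Cl)c3)n2)cc1` carries a 3-chlorophenyl group on the shared core. In an assay on microsomes from brain for inhibition of Fatty-acid amide hydrolase 1 (Rattus norvegicus), read by fluorescence and HPLC, with a stated time of 60 min (a lower number here means a stronger inhibitor, a higher number a weaker inhibitor), compound 1 gives 24 nM. Compound 2 `CCCCCCCCc1ccc(OCC(=O)Cn2nnc(-c3ccc(C(=O)OC)cc3)n2)cc1` gives 29 nM, and compound 3 `CCCCCCCCc1ccc(OCC(=O)Cn2nnc(-c3ccncc3)n2)cc1` gives 24 nM. Compound 1 therefore stands level with compound 3 at the digits shown, and together they carry the lowest of the three numbers, although every gap among the three lies within the scatter: a 1.2-fold higher number from compound 1 to compound 2 (0.08 log units; within the scatter), no change at the digits printed from compound 1 to compound 3 (within the scatter) and a 1.2-fold lower number from compound 2 to compound 3 (0.08 log units; within the scatter).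

Compound 4 `CCCCCCCCc1ccc(OCC(=O)Cn2nnc(CCC(=O)O)n2)cc1` has not yet been measured. It differs from compound 1 in one place: 2-carboxyethyl in place of 3-chlorophenyl on an aromatic carbon. Each measured step exchanged one six-membered aromatic ring for another, and all of them left the number essentially unchanged. None of them removed the ring altogether or brought in a carboxylic acid, so they bear on compound 4 only by showing that varied groups on this aromatic carbon are tolerated. The new change is larger than any measured step, and some weakening beyond the scatter is expected, with wide uncertainty in either direction. For compound 4 the expected step is a 4.2-fold higher number from compound 1 to compound 4 (0.62 log units; beyond the scatter). Compound 4 is estimated at 100 nM, with a range from 25 nM to 500 nM.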

Compound 4, half-maximal inhibitory concentration: 30 nM
Compound 4: the middle estimate sits 3.3-fold (0.52 log units) above what was measured; low and high end bracket the measured number.
By their numbers in this assay, from the lowest: compounds 1, 3, 2 and 4 (each within the scatter of the next).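

In this assay the aromatic ring on this carbon gives way to an open chain, and the step is a 1.3-fold higher number from compound 1 to compound 4 (0.10 log units; within the scatter) and no larger when the chain replaces either of the other two rings, with a 1.3-fold higher number from compound 3 to compound 4 (0.10 log units; within the scatter) and a 1.0-fold higher number from compound 2 to compound 4 (0.01 log units; within the scatter) as the readings. For the compounds shown here, the earlier compounds showed only that one six-membered aromatic ring could stand in for another, whereas compound 4 shows that, in this series, the number holds with no ring on this carbon at all and with a carboxylic acid at the end of a chain in its place. Nothing measured here gives a reason for this result, so the observation stands without an explanation.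

The compounds shown leave open how far this freedom extends, since a single chain cannot say whether its length or its end group matters: a shorter carboxymethyl chain, a longer carboxypropyl chain, the methyl ester of the 2-carboxyethyl chain or an amine at the chain end would each test this. A plain ethyl group on the same carbon would also show whether the carboxylic acid contributes anything to the number.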